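A few compounds are considered here, and "the series" means these few. Any claim that something is new, unique, unknown or untested is made for them only; others in the source may bear on it.

Three compounds built on one shared core have been run in a functional assay on the whole organism (Tail, strain ICR) with Mus musculus as the target, in the tail flick test, with a stated time of 90 min, at a dose of 25 umol/kg by the oral route; a higher number here means a stronger effect of the compound at the dose given, a lower number a weaker effect. Compound 1 `C[C@H](NC(=O)CN(c1nc(Cl)nc2[nH]cnc12)C1CC1)C(=O)OCc1ccccc1` gives 44.2%. Compound 2 `CC[C@H](C)[C@H](NC(=O)CN(c1nc(Cl)nc2[nH]cnc12)C1CC1)C(=O)O` gives 27.4%, and compound 3 `NC(=O)C[C@H](NC(=O)CN(c1nc(Cl)nc2[nH]cnc12)C1CC1)C(=O)O` gives 20.1%. Compound 3 therefore holds the lowest of the three numbers: its gap to compound 2 lies within the usual scatter, while its gap to compound 1 lies beyond it. Among the compounds with values here, only one pair of measured compounds differs in a single place, and that step, a number 7.3 percentage points lower from compound 2 to compound 3 (within the scatter), replaced sec-butyl with carbamoylmethyl on a saturated chain carbon bound to an amide-type nitrogen and a carbonyl carbon without moving the number beyond the scatter.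

Compound 4 `CC(C)[C@H](NC(=O)CN(c1nc(Cl)nc2[nH]cnc12)C1CC1)C(=O)O` has not yet been measured in this assay. It differs from compound 3 in one place: isopropyl in place of carbamoylmethyl on a saturated chain carbon bound to an amide-type nitrogen and a carbonyl carbon. The measured step bearing on this exchange is the one already described, which went from a plain alkyl group to carbamoylmethyl at the same place and proved small. Its reverse, back to a plain alkyl group, is expected to be similarly small, so the estimated step is a number 5.9 percentage points higher from compound 3 to compound 4 (within the scatter), a change within the scatter. Compound 4 is estimated to give 26%, with a likely range from 13% to 40%.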

Compound 4, a percentage reported as activity, at one dose (the size of the read-out at that dose, not a potency): 30.3%
Beside the measured number, compound 4's estimate is 4.3 percentage points below it; low and high end bracket the measured number.
By their numbers in this assay, from the lowest: compounds 3, 2 and 4 (each within the scatter of the next, the first and the last beyond it); then compound 1.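

In this assay, within the data shown here, the exchange of carbamoylmethyl for isopropyl on a saturated chain carbon bound to an amide-type nitrogen and a carbonyl carbon gives a number 10.2 percentage points higher from compound 3 to compound 4 (beyond the scatter) and is the first change at this place to pass the usual scatter, though only modestly. Going from sec-butyl to isopropyl, which puts hydrogen in place of methyl further along the chain, gives a number 2.9 percentage points higher from compound 2 to compound 4 (within the scatter) and so leaves the two plain alkyl groups indistinguishable here. Compound 3 is therefore separated from compound 4 but not from compound 2, so the drop seen with carbamoylmethyl is small and rests on a single pair, and no measurement at hand offers a reason for it.

Still open, from the compounds shown here alone, is how a group of another kind at this place would behave, such as a chain ending in an amine or a carboxylic acid, or a longer alkyl chain. Compound 1 differs from the others both at this place and in carrying a benzyl ester, so the compounds shown cannot say how much of its number belongs to the ester and how much to the group on the chain.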